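Adding a (1-methylpyrrolidin-2-yl)methoxy group to compound 1

The source may hold more compounds than are shown below. What is called first, only, known or untested is meant among the compounds shown, and "the series" means these compounds.

Among the compounds with values here, in a functional assay on MDA-MB-436 cells (Homo sapiens) for antiproliferative activity, read by MTT assay, with a stated time of 48 h (on this read-out lower numbers stand for stronger inhibition and higher numbers for weaker inhibition), compound 1 (`C=CS(=O)(=O)N1CCN(c2ncnc3sc(-c4ccc(OC)nc4)cc23)CC1`) gives 11900 nM and holds the lower of the two numbers so far. Compound 2 (`C=CS(=O)(=O)N1CCN(c2ncnc3sc(-c4cccs4)cc23)CC1`) gives 39000 nM on the same read-out. Compound 3 (`C=CS(=O)(=O)N1CCN(c2nc(OC[C@H]3CCCN3C)nc3sc(-c4ccc(OC)nc4)cc23)CC1`) carries (1-methylpyrrolidin-2-yl)methoxy in place of hydrogen on an aromatic carbon between two ring nitrogen atoms: (1-methylpyrrolidin-2-yl)methoxy in place of hydrogen on an aromatic carbon and nothing else separates it from compound 1. Within the data shown here, only one measured step exists, a 3.3-fold higher number from compound 1 to compound 2 (0.52 log units; beyond the scatter) and it exchanges a different group, thiophen-2-yl for 6-methoxypyridin-3-yl, so it offers a scale but no direction. Among the measured compounds shown here, no measured compound carries a substituent at the new place. A modest step is therefore expected in this assay, no larger than that one and tentatively toward a lower number. The estimated step is a 2.0-fold lower number from compound 1 to compound 3 (0.30 log units; within the scatter) with its direction uncertain. For compound 3 the expected value is 6000 nM with an estimated range of 1500 nM to 24000 nM around it.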

Compound 3, half-maximal inhibitory concentration: 4980 nM
The estimate for compound 3 lay 1.2-fold (0.08 log units) above the measured number, and the stated range covers the measured number.
By their numbers in this assay, from the lowest: compound 3; then compound 1; then compound 2.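

At the aromatic carbon between two ring nitrogen atoms, adding (1-methylpyrrolidin-2-yl)methoxy gives a 2.4-fold lower number from compound 1 to compound 3 (0.38 log units; beyond the scatter) in this assay. Within the data shown here, this is the first measured substituent at this place, and it shows that the place accepts a group carrying a five-membered non-aromatic ring while the number moves modestly lower, beyond the scatter. No supporting data bear on why the number moves in this direction.

The compounds shown leave open whether the step needs the whole (1-methylpyrrolidin-2-yl)methoxy group, or whether a plain methoxy group or a simple dimethylamine at the same place would give a similar number. They also leave open whether the mirror-image form of the group, or the same group on compound 2, would give a step of this size.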